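The source may hold more compounds than are shown below. What is called first, only, known or untested is meant among the compounds shown, and "the series" means these compounds.

Two compounds share one core and differ only in the ring attached to the aromatic nitrogen. Compound 1 `Cn1ccc2c(Oc3ccc(NC(=O)c4cn(-c5ccccc5)c5ccccc5c4=O)cc3F)ccnc21` carries a plain phenyl on that nitrogen; in a functional assay on MCF7 cells (Homo sapiens) for inhibition, read by MTT assay, with a stated time of 72 h (a higher number here means a weaker inhibitor, a lower number a stronger inhibitor), compound 1 gives 2790 nM. Compound 2 `Cn1ccc2c(Oc3ccc(NC(=O)c4cn(-c5ccc(Br)cc5)c5ccccc5c4=O)cc3F)ccnc21` carries a 4-bromophenyl there, and in this assay compound 2 gives 1830 nM. Within the data shown here, the single measured step is a 1.5-fold lower number from compound 1 to compound 2 (0.18 log units; within the scatter), bromo in place of hydrogen on an aromatic carbon, and it does not exceed the scatter of the measurement. Among the measured compounds shown here, on the two numbers so far, compound 2 has the lower one, but its gap to compound 1 is within the scatter, so no order between the two can be claimed.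

Compound 3 `Cn1ccc2c(Oc3ccc(NC(=O)c4cn(-c5ccc(C(F)(F)F)cc5Cl)c5ccccc5c4=O)cc3F)ccnc21` is the next member of the series and is not yet measured. It differs from compound 2 by 2-chloro-4-(trifluoromethyl)phenyl in place of 4-bromophenyl on an aromatic nitrogen. For the measured compounds named here, the only step that bears on this change is a 1.5-fold lower number from compound 1 to compound 2 (0.18 log units; within the scatter), which was small; it speaks for a modest effect of substituents on this ring. Compound 3 is therefore expected to be close to compound 2, with a step of about a 1.2-fold lower number from compound 2 to compound 3 (0.09 log units; within the scatter) and no clear direction beyond the scatter. The estimate for compound 3 in this assay is 1500 nM, with a range from 500 nM to 4500 nM.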

Compound 3, half-maximal inhibitory concentration: 190 nM
For compound 3 the middle estimate is 7.9-fold (0.90 log units) above the measured one, and the stated range ends above it.
By their numbers in this assay, from the lowest: compound 3; then compounds 2 and 1 (each within the scatter of the next).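

In this assay, the ring on the aromatic nitrogen now proves able to move the number well beyond the scatter: replacing 4-bromophenyl with 2-chloro-4-(trifluoromethyl)phenyl gives a 9.6-fold lower number from compound 2 to compound 3 (0.98 log units; beyond the scatter) and marks this position as one where the substituents can matter, which the bromo step alone did not reveal. Measured against the plain phenyl, the same ring gives a 15-fold lower number from compound 1 to compound 3 (1.17 log units; beyond the scatter) and leaves compound 3 as the strongest inhibitor of the three shown, with both of its steps beyond the scatter. Nothing available explains why this ring gives the lower number.

The change from compound 2 to compound 3 removes the bromo group and brings in the chloro and trifluoromethyl groups together, so these three compounds cannot show how much of the step belongs to each group or whether the two must be present together. From the compounds shown here alone, it also remains open how the number would respond to quite different groups on this ring, such as an amine, a carboxylic acid or a longer chain.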